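A few compounds are considered here, and "the series" means these few. Any claim that something is new, unique, unknown or untested is made for them only; others in the source may bear on it.

Compound 1 `COC(=O)C1=C(C)N=C(C)/C(=C(/O)OC)C1c1cccc(NC(=O)NCCNC2CCN(c3ccccc3C)CC2)c1` and compound 2 `COC(=O)C1=C(C)N=C(C)/C(=C(/O)OC)C1c1cccc(NC(=O)NCCNC2CCN(c3ccccc3C(F)(F)F)CC2)c1` share one core and differ only in the group on the aromatic carbon, methyl or trifluoromethyl. In an assay on SK-N-MC cells for inhibition of Neuropeptide Y receptor type 1 (Homo sapiens) (a lower number here means a stronger inhibitor, a higher number a weaker inhibitor), compound 1 gives 4 nM, and compound 2 gives 31 nM, the higher of the two numbers, with a 7.8-fold higher number from compound 1 to compound 2 (0.89 log units; beyond the scatter). Compound 3 `COC(=O)C1=C(C)N=C(C)/C(=C(/O)OC)C1c1cccc(NC(=O)NCCNC2CCN(c3ccccc3C#N)CC2)c1` carries cyano in place of trifluoromethyl on an aromatic carbon. Among the measured compounds shown here, only that single measured step bears on this change, and it says nothing direct about a nitrile, so no firm direction can be read from it, though a partial return toward compound 1 seems possible. Compound 3 is therefore expected to give about 15 nM, in a range from 4 nM to 60 nM, an expected step of a 2.1-fold lower number from compound 2 to compound 3 (0.32 log units; beyond the scatter).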

Compound 3, half-maximal inhibitory concentration: 3 nM
Estimate against measurement, compound 3: 5.0-fold (0.70 log units) above; measured number below the stated range.
By their numbers in this assay, from the lowest: compounds 3 and 1 (each within the scatter of the next); then compound 2.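

In this assay, the change from 2-(trifluoromethyl)phenyl to 2-cyanophenyl gives a 10-fold lower number from compound 2 to compound 3 (1.01 log units; beyond the scatter), so the loss seen with trifluoromethyl does not extend to every replacement of methyl at this place. Cyano and methyl cannot be told apart here, with a 1.3-fold lower number from compound 1 to compound 3 (0.12 log units; within the scatter). Nothing measured here explains this result. The compounds shown leave open whether a chlorine atom, a methoxy group or a carboxylic acid at this place would match compound 1 and compound 3. They also leave open whether cyano elsewhere on this ring would do the same.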